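Coumarin-bearing pyrazoline amides: a second amine on the acetyl arm

This account rests on a few compounds, and the source may have more. Where it says the series, first, only, none or still open, it means among the compounds named here.

Two compounds in the set carry a number in a functional assay on MGC-803 cells (Homo sapiens) for cytotoxicity, read by MTT assay, with a stated time of 48 h; a higher number here means a weaker inhibitor, a lower number a stronger inhibitor. Compound 1 `CCN(CC)CC(=O)N1N=C(C)CC1c1ccccc1O` gives 39800 nM in this assay. Compound 2 `CCNCC(=O)N1N=C(c2cc3ccccc3oc2=O)CC1c1ccccc1` gives 26600 nM in this assay, and the gap between compound 2 and compound 1 is within the scatter of repeated measurements, so the two are not separated by the numbers. For the measured compounds named here, no step between measured compounds that differ in one place is available, so no measured step sets a scale for the series.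

Compound 3 `CCN(CC)C1CCN(CC(=O)N2N=C(c3cc4ccccc4oc3=O)CC2c2ccccc2)CC1` has not been measured in this assay. It differs from compound 2 in one place (4-(diethylamino)piperidin-1-yl in place of ethylamino on a saturated chain carbon bound to a carbonyl carbon). Nothing in the two measured numbers points to a change of this kind, and the step from compound 2 to compound 3 is expected to be small, toward a lower number, and quite possibly within the scatter: a 1.8-fold lower number from compound 2 to compound 3 (0.25 log units; within the scatter). Compound 3 is therefore estimated at 15000 nM in this assay, with a range from 4000 nM to 60000 nM, resting only on the numbers of compound 2 and compound 1.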

Compound 3, half-maximal inhibitory concentration: 32400 nM
Compound 3: the middle estimate sits 2.2-fold (0.33 log units) below what was measured; the range from low to high includes it.
By their numbers in this assay, from the lowest: compounds 2, 3 and 1 (each within the scatter of the next).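

In this assay, the first step read at this position is a 1.2-fold higher number from compound 2 to compound 3 (0.09 log units; within the scatter), so 4-(diethylamino)piperidin-1-yl in place of ethylamino, on a saturated chain carbon bound to a carbonyl carbon, leaves the two compounds unseparated. That holds for a substantial change: the entering group has 11 heavy atoms and a six-membered non-aromatic ring, against 3 heavy atoms and no ring in the group that leaves, and its 0 hydrogen-bond donors stand against 1. No measurement at hand bears on why the numbers of this pair stay together.

Still open, on these data alone, is whether any group at this position can move the number beyond the scatter, a question that a morpholin-4-yl ring, a carboxylic acid or a longer alkyl chain on the same carbon would help to answer. For the compounds shown here, the contribution of the rest of the core also remains unread, since the only single-place step in hand lies at this one position.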